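Bis-anilino furazanopyrazine series: ethoxy for difluoro swap

A few compounds are considered here, and "the series" means these few. Any claim that something is new, unique, unknown or untested is made for them only; others in the source may bear on it.

Measured so far:
compound 1, `CCOc1cccc(Nc2nc3nonc3nc2Nc2cccc(OCC)c2)c1`, 10100 nM
compound 2, `Cc1ccc(Nc2nc3nonc3nc2Nc2ccc(C)c(C)c2)cc1C`, > 100000 nM
compound 3, `Fc1ccccc1Nc1nc2nonc2nc1Nc1cccc(F)c1F`, 500 nM

The read-out throughout is an assay on mitochondria from L6 cells (Rattus norvegicus) for activation, with a stated time of 90 min; a lower number here means that less compound is needed, a higher number that more compound is needed for the effect. Compound 3 gives 500 nM and stands lowest of the two numbers obtained; the nearest number, that of compound 1 at 10100 nM, lies well above it, beyond the scatter. Compound 2 returns only a limit, > 100000 nM, so its value is not a number; this is the case described by the limit of > 100000 nM in this assay, at which 1 of the 3 values shown sits.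

Among the compounds with values here, no pair of measured compounds differs in only one place, so no measured step is available. Compound 4, `CCOc1ccc(Nc2nc3nonc3nc2Nc2ccccc2F)cc1`, differs from compound 3 in one place: 4-ethoxyphenyl in place of 2,3-difluorophenyl on a nitrogen on an aromatic ring. The other anilino group of compound 3 is kept unchanged.

Within the series the two compounds carrying alkoxy or methyl substituents, compound 1 and compound 2, sit far above compound 3, while compound 3 with fluorine substituents sits lowest. Compound 4 carries one ring of each kind, so the step from compound 3 to compound 4 is expected to go upward, by an amount estimated as a 6.0-fold higher number from compound 3 to compound 4 (0.78 log units; beyond the scatter), a step beyond the scatter but short of the gap to compound 1. For compound 4 the expected value in this assay is therefore 3000 nM, with a range from 800 nM to 15000 nM.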

Compound 4, half-maximal effective concentration: 3800 nM
For compound 4 the middle estimate is 1.3-fold (0.10 log units) below the measured one; the measured number falls inside the stated range.
By their numbers in this assay, from the lowest: compound 3; then compound 4; then compound 1. At a limit, above all of these: compound 2.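

In this assay, within the data shown here, replacing 2,3-difluorophenyl with 4-ethoxyphenyl on a nitrogen on an aromatic ring, with the other anilino group kept unchanged, gives the first single-place step: a 7.6-fold higher number from compound 3 to compound 4 (0.88 log units; beyond the scatter). Among these compounds, this shows that the group at this one position can move the number beyond the scatter on its own, something the earlier compounds could not show, since none of them formed a pair differing in only one place. The entering group carries an oxygen and a hydrogen-bond acceptor that the leaving group lacks, but no measured property in the data ties the step to either feature or to the loss of the fluorines.

As far as these compounds go, with a single change at this position, it remains open whether the step follows from the ethoxy group, from its place on the ring, or from the removal of the 2,3-difluoro pattern. Also open, from the compounds shown here alone, are how an amine or a carboxylic acid in place of the ethoxy group would read in this assay, and whether the same change on the other anilino group would give a step of similar size.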